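Pyrrolidinyl for dimethylamino on the second core

A few compounds are considered here, and "the series" means these few. Any claim that something is new, unique, unknown or untested is made for them only; others in the source may bear on it.

Compound 1 `CN(C)CCn1c(=O)sc2cc(S(=O)(=O)N(C)c3cccc4ccccc34)ccc21` gives 0% in an assay on HEK293 cells for displacement of a labelled ligand from 5-hydroxytryptamine receptor 6 (Homo sapiens), read by radioligand binding, with a stated time of 60 min, tested at 100 nM; a higher number here means more inhibition at the concentration tested (going by the name of the read-out), a lower number less inhibition. Compound 2 `CN(c1cccc2ccccc12)S(=O)(=O)c1ccc2c(c1)sc(=O)n2CCN1CCCC1` carries the change pyrrolidin-1-yl in place of dimethylamino on a saturated chain carbon, two bonds along the chain from an aromatic nitrogen and gives 40% in this assay; the step is a number 40 percentage points higher from compound 1 to compound 2 (beyond the scatter). Compound 3 `CN(C)CCn1c(=O)sc2cc(S(=O)(=O)Nc3ccccc3)ccc21` gives 21% in this assay; the difference between the core of compound 3 and the core of compound 1 is not broken down here, and their two values show compound 3 as the higher of the pair. Compound 4 `O=c1sc2cc(S(=O)(=O)Nc3ccccc3)ccc2n1CCN1CCCC1` has not yet been measured in this assay. It differs from compound 3 by pyrrolidin-1-yl in place of dimethylamino on a saturated chain carbon, two bonds along the chain from an aromatic nitrogen, which is the same change as from compound 1 to compound 2, with the place described in the same words. That change has been seen once in this set, and it made a large step. On the core of compound 3 a step in the same direction is expected, somewhat smaller since compound 3 does not start from zero but from 21%. The expected step is a number 34 percentage points higher from compound 3 to compound 4 (beyond the scatter), resting on the earlier step of a number 40 percentage points higher from compound 1 to compound 2 (beyond the scatter). In this assay compound 4 is expected to give 55%, estimated between 30% and 80%.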

Compound 4, a percentage reported as inhibition, at one concentration (the size of the read-out at that concentration, not a potency): 37%
Estimate against measurement, compound 4: 18 percentage points above, and the stated range covers the measured number.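

In this assay the change from dimethylamino to pyrrolidin-1-yl moves the number the same way on both cores, but the size of the step differs: the same change on two cores in this assay, a number 40 percentage points higher (beyond the scatter) from compound 1 to compound 2 and a number 16 percentage points higher (beyond the scatter) from compound 3 to compound 4, 24 percentage points apart, beyond the scatter of two such steps The direction therefore carries over to the core of compound 3, with a number 16 percentage points higher from compound 3 to compound 4 (beyond the scatter), while the size of the earlier step does not. Two pairs give no general rule for the size of this step on other cores, and inhibition read at one concentration is not a potency, so neither pair gives a change in potency.

From the compounds shown here alone, it remains open whether piperidin-1-yl, morpholin-4-yl or a longer chain such as 3-(pyrrolidin-1-yl)propyl would give a step in the same direction on either core. Also open is which part of the difference between the core of compound 1 and the core of compound 3 goes with the smaller step, since the compounds shown present that difference only as a whole.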